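Trifluoromethyl for chloro on the benzyloxy ring

The source may report more compounds than this note shows. Statements on the series, on what has been measured and on what is new or still open speak of the compounds shown alone.

Compound 3 `Cc1nc2c(OCc3ccc(Cl)cc3)cccn2c1N` gives 66% in a functional assay on the whole organism with Rattus norvegicus as the target, at a dose of 40 mg/kg by the intraperitoneal route (a higher number here means more inhibition at the dose given (going by the name of the read-out), a lower number less inhibition), the lowest of the three numbers measured. Compound 1 `Cc1nc2c(OCc3ccccc3)cccn2c1N` gives 99% and compound 2 `Cc1nc2c(OCc3ccc(F)cc3)cccn2c1N` gives 95%; the step of a number 4 percentage points lower from compound 1 to compound 2 (within the scatter) lies within the scatter, whereas a number 33 percentage points lower from compound 1 to compound 3 (beyond the scatter) and a number 29 percentage points lower from compound 2 to compound 3 (beyond the scatter) both lie beyond it. Compound 4 `Cc1nc2c(OCc3ccc(C(F)(F)F)cc3)cccn2c1N` differs from compound 3 by trifluoromethyl in place of chloro on an aromatic carbon. Going by the values given here, no measured step covers trifluoromethyl; the only substituent changes on that ring are the two above, both pointing downward once chloro enters. The expected step of a number 14 percentage points lower from compound 3 to compound 4 (beyond the scatter) is therefore a modest further fall in this assay, with wide uncertainty. Compound 4 is estimated at 52%, range 22% to 80%.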

Compound 4, a percentage reported as inhibition, in the whole organism at one dose (the size of the read-out at that dose, not a potency): 78%
Beside the measured number, compound 4's estimate is 26 percentage points below it; measured number inside the range.
By their numbers in this assay, from the lowest: compound 3; then compound 4; then compounds 2 and 1 (each within the scatter of the next).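

In this assay, the step of a number 12 percentage points higher from compound 3 to compound 4 (beyond the scatter) shows that the fall seen on going to chloro does not continue with trifluoromethyl at this position, para to a large group. Trifluoromethyl still leaves a cost against both hydrogen and fluoro, with a number 21 percentage points lower from compound 1 to compound 4 (beyond the scatter) and a number 17 percentage points lower from compound 2 to compound 4 (beyond the scatter) on the same read-out. The position therefore shows no single downward run from hydrogen through fluoro and chloro to trifluoromethyl.

No data here explain why trifluoromethyl stands above chloro. As far as these compounds go, whether a methoxy group, an amine or a carboxylic acid in the same place would stay closer to hydrogen remains open.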